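This account rests on a few compounds, and the source may have more. Where it says the series, first, only, none or still open, it means among the compounds named here.

Measured so far:
compound 1 `COC(=O)C1=C(C)N(c2ccc(Cl)c(Cl)c2)C(C)=C(C(=O)OC)C1[C@@H]1O[C@H]2OC(C)(C)O[C@H]2[C@@H]1O` gives 29.9 ug/mL
compound 2 `COC(=O)C1=C(C)N(c2ccc(Cl)cc2)C(C)=C(C(=O)OC)C1[C@@H]1O[C@H]2OC(C)(C)O[C@H]2[C@@H]1O` gives 35.5 ug/mL

For the measured compounds named here, only these two compounds have numbers so far in an ADME assay on J774.A1 cells (Mus musculus) for cytotoxicity, read by MTT assay, with a stated time of 72 h (on this read-out lower numbers stand for higher toxicity in this test and higher numbers for lower toxicity in this test), and compound 2 at 35.5 ug/mL sits within the usual scatter of compound 1. The next compound is compound 3 `COC(=O)C1=C(C)N(c2ccc(Cl)cc2)C(C)=C(C(=O)OC)C1[C@@H]1O[C@H]2OC(C)(C)O[C@H]2[C@@H]1OC`, which carries one change from compound 2: methyl in place of hydrogen on an oxygen on a saturated carbon in short, methyl in place of hydrogen on an oxygen on a saturated carbon, so that hydroxy becomes methoxy.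

Going by the values given here, the only measured step, a 1.2-fold higher number from compound 1 to compound 2 (0.07 log units; within the scatter), concerns hydrogen in place of chloro on an aromatic carbon. Among the compounds with values here, it is a different change at a different place, so it bears on this one only indirectly, and no measured pair tests the hydroxy group. Within the data shown here, with that single small step as the sole guide, neither direction can be favoured, and no step beyond the scatter is expected in this assay here. The estimated outcome is a 1.1-fold lower number from compound 2 to compound 3 (0.03 log units; within the scatter) and nothing larger is expected. For compound 3 the expected value is 33 ug/mL with an estimated range from 15 ug/mL to 70 ug/mL on repeat measurement.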

Compound 3, half-maximal cytotoxic concentration: 82.4 ug/mL
For compound 3 the middle estimate is 2.5-fold (0.40 log units) below the measured one; the measured number lies above the stated range.
By their numbers in this assay, from the lowest: compounds 1 and 2 (each within the scatter of the next); then compound 3.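

Replacing hydroxy with methoxy, on an oxygen on a saturated carbon, gives a 2.3-fold higher number from compound 2 to compound 3 (0.37 log units; beyond the scatter) in this assay, and on this read-out that means lower toxicity in this test. This is the first change among these compounds to move the number beyond the scatter, whereas the aromatic change gave only a 1.2-fold higher number from compound 1 to compound 2 (0.07 log units; within the scatter) and so showed no clear effect. The result therefore marks this oxygen as a place where even one added methyl can be seen in this assay, though nothing available explains the rise.

Still open, going by these compounds, is whether a longer chain on this oxygen, such as ethyl, would raise the number further, or whether an amine in place of the hydroxy would bring a similar shift. It is also unknown whether the same hydroxy to methoxy change would act the same way on compound 1, which carries the additional chloro group on its aromatic ring, since a single pair cannot show that the step carries over to other members of the series.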